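From 3,4-difluorophenyl to 4-methoxyphenyl at an assay limit

The source may report more compounds than this note shows. Statements on the series, on what has been measured and on what is new or still open speak of the compounds shown alone.

Of the compounds shown here, three sharing one core have been measured in a functional assay on M21 cells (Homo sapiens) for antiproliferative activity, read by sulforhodamine B assay, with a stated time of 48 h (on this read-out higher numbers stand for weaker inhibition and lower numbers for stronger inhibition), so far. Compound 1 (`CCN1CCN(c2ccc(S(=O)(=O)Oc3ccc(OC)cc3)cc2)C1=O`), with an ethyl chain and a 4-methoxyphenyl group, gives 26000 nM as a true number. Compound 2 (`CCCCN1CCN(c2ccc(S(=O)(=O)Oc3ccccc3)cc2)C1=O`), with a butyl chain and a phenyl group, reads > 100000 nM and this is a limit of the assay. Compound 3 (`CCCCN1CCN(c2ccc(S(=O)(=O)Oc3ccc(F)c(F)c3)cc2)C1=O`), also butyl but with a 3,4-difluorophenyl group, reads > 100000 nM and this too is a limit. Compound 3 thus stands at the limit of > 100000 nM in this assay, at which 2 of the 3 values shown sit, and has no number of its own. Among the measured compounds shown here, the one measured step, a step that the two limits leave unreadable from compound 2 to compound 3, gives no size to build on.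

Compound 4 (`CCCCN1CCN(c2ccc(S(=O)(=O)Oc3ccc(OC)cc3)cc2)C1=O`) keeps the butyl chain and takes 4-methoxyphenyl in place of 3,4-difluorophenyl on an oxygen. Only compound 1 with its 26000 nM reading bears on this group, and it carries the ethyl chain instead. Stronger inhibition is therefore expected, as an estimated at least 2.8-fold lower number from compound 3 to compound 4 (0.45 log units; beyond the scatter), though a reading at the limit remains possible. Compound 4 is estimated at 35000 nM with an expected range of 10000 nM to 100000 nM on this read-out.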

Compound 4, half-maximal inhibitory concentration: > 100000 nM
Compound 4: a limit, no number; the forecaster's own chance of this, stated with the estimate: 35%; middle value at least 2.8-fold (0.45 log units) away from the limit.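

In this assay, the 4-methoxyphenyl group on the oxygen does not bring a butyl compound to a readable number: compound 4 reads > 100000 nM, which is a limit. With 4-methoxyphenyl held fixed, the one readable step is an at least 3.8-fold higher number from compound 1 to compound 4 (0.58 log units; beyond the scatter), so the only true number among these compounds goes with the ethyl chain and not with the butyl chain. The steps among the butyl compounds cannot be read, and the set now gathers at one boundary: the limit of > 100000 nM in this assay, at which 3 of the 4 values shown sit.

On these data alone, it remains open how far each butyl compound lies past that limit, and so whether phenyl, 3,4-difluorophenyl and 4-methoxyphenyl differ at all on this chain. Also open, as far as these compounds go, is whether a methyl or a propyl chain in place of butyl would give a true number with 4-methoxyphenyl.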